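The source may report more compounds than this note shows. Statements on the series, on what has been measured and on what is new or still open speak of the compounds shown alone.

Compound 1 `O=C1C=C(Nc2cccc(F)c2)C(=O)c2c1nc1n2[C@H]2OC[C@@H](O)[C@H]2OC1`: 5500 nM
Compound 2 `O=C1C=C(Nc2ccc(Br)cc2)C(=O)c2c1nc1n2[C@H]2OC[C@@H](O)[C@H]2OC1`: 2580 nM
Compound 3 `CCOc1ccccc1NC1=CC(=O)c2nc3n(c2C1=O)[C@H]1OC[C@@H](O)[C@H]1OC3`: > 4000 nM (a limit, not a number)

All three were tested in a functional assay on MCF7 cells (Homo sapiens) for inhibition, read by sulforhodamine B assay (a lower number here means a stronger inhibitor, a higher number a weaker inhibitor), and they differ only in the aromatic ring on the amine nitrogen.

Compound 3 carries 2-ethoxyphenyl there. Its reading of > 4000 nM is a limit of the assay and not a number. Its place among the three is therefore only partly known. The data show an at least 1.5-fold higher number from compound 2 to compound 3 (0.19 log units; that floor lies within the scatter) and a step that the limit leaves unreadable from compound 1 to compound 3.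

The next compound, compound 4 `O=C1C=C(Nc2ccccc2)C(=O)c2c1nc1n2[C@H]2OC[C@@H](O)[C@H]2OC1`, removes the ethoxy group: hydrogen in place of ethoxy on an aromatic carbon. In words, this is hydrogen in place of ethoxy on an aromatic carbon, ortho to a large group, so 2-ethoxyphenyl becomes phenyl.

Going by the values given here, no measured step makes this exact change, so the evidence is indirect. Among the compounds with values here, the one fully readable step, a 2.1-fold lower number from compound 1 to compound 2 (0.33 log units; beyond the scatter), is modest and shows one substituted ring exchanged for another. Within the data shown here, the only true numbers are that compound 1 gives 5500 nM and compound 2 gives 2580 nM, and compound 4 is expected to fall near them.

In this assay, the expected change is small and towards a lower number, and it may stay within the scatter: an at least 1.1-fold lower number from compound 3 to compound 4 (0.05 log units; that floor lies within the scatter). The estimate for compound 4 is 3500 nM, with an expected range from 1500 nM to 8000 nM.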

Compound 4, half-maximal inhibitory concentration: > 4000 nM
Compound 4 gave a limit, no number (the forecaster's own chance of this, stated with the estimate: 25%); middle value at least 1.1-fold (0.05 log units) away from the limit.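

In this assay compound 4 gives > 4000 nM, a limit and not a number. The plain phenyl ring, which carries no substituent, therefore gives no readable gain over 2-ethoxyphenyl, and the steps from compound 3 and from compound 1 to compound 4 cannot be read because these readings sit at the same cut-off: the limit of > 4000 nM in this assay, at which 2 of the 4 values shown sit. Compared with the bromo-bearing ring, taking bromo away gives an at least 1.5-fold higher number from compound 2 to compound 4 (0.19 log units; that floor lies within the scatter), so this floor alone does not show that the bromo group matters for this change.

From the compounds shown here alone, how far beyond the limit compound 3 and compound 4 truly lie remains open, and so does whether either one truly differs from compound 1 or from the other. The compounds shown also leave open what an amine, a carboxylic acid or a longer chain on this aromatic ring would do to the reading, and whether any of these would bring the value clearly lower than those seen so far.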